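A few compounds are considered here, and "the series" means these few. Any claim that something is new, unique, unknown or untested is made for them only; others in the source may bear on it.

Working notes on the series. In an ADME assay on the whole organism for pharmacokinetics, with Rattus norvegicus as the target, read by LC-MS, at a dose of 10 mg/kg by the oral route (a higher number here means more compound in the circulation at the dose given, a lower number less compound in the circulation), compound 1 `COc1ccc2c(c1)C(=O)N(C[C@]1(c3cc4ncccc4o3)C(=O)N(COC(=O)C(C)(C)C)C(=O)N1COC(=O)C(C)(C)C)C2` gives 1920 ng.h/mL, and compound 2 `COc1ccc2c(c1F)C(=O)N(C[C@@]1(c3cc4nc(N5CCN(C)CC5)ccc4o3)NC(=O)N(COC(=O)C(C)(C)C)C1=O)C2` gives 5350 ng.h/mL. Compound 2 holds the higher of the two numbers, and the gap between them lies beyond the scatter of repeated measurements. The two compounds differ in more than one place, so that gap cannot be assigned to any single structural change.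

The next compound is compound 3 `COc1ccc2c(c1F)C(=O)N(C[C@@]1(c3cc4nc(N)ccc4o3)NC(=O)N(COC(=O)C(C)(C)C)C1=O)C2`. It carries amino in place of 4-methylpiperazin-1-yl on an aromatic carbon, next to the ring nitrogen (amino in place of 4-methylpiperazin-1-yl on an aromatic carbon). The rest of the structure matches compound 2. Among the compounds with values here, no measured pair isolates this change, so its direction in this assay is a judgement with little support. Within the data shown here, the starting point is compound 2 at 5350 ng.h/mL, the higher of only two numbers, and a modest fall seems more likely than a further rise. The estimated step is small and downward, a 1.5-fold lower number from compound 2 to compound 3 (0.18 log units; within the scatter), and it may not clear the scatter. For compound 3 the expected value is 3500 ng.h/mL, with an estimated range of 1200 ng.h/mL to 10000 ng.h/mL.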

Compound 3, area under the concentration-time curve: 216 ng.h/mL
Compound 3: middle estimate off by 16-fold (1.21 log units), on the high side, outside the stated range (below it).
By their numbers in this assay, from the lowest: compound 3; then compound 1; then compound 2.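

Within the data shown here, this position is far from neutral in this assay: the exchange of 4-methylpiperazin-1-yl for amino on the aromatic carbon next to the ring nitrogen gives a 25-fold lower number from compound 2 to compound 3 (1.39 log units; beyond the scatter) as the first single-change step, and it is a large one. The rest of the structure is shared, so the whole of that step belongs to this one place, where a six-membered non-aromatic ring with 2 hetero atoms gives way to a single nitrogen. The earlier pair could not assign any of its gap to one structural change, whereas this pair ties a large change in compound exposure after oral dosing to this substituent.

Going by these compounds, what remains open is whether the number recovers gradually or only with the complete 4-methylpiperazin-1-yl group, a question that dimethylamino, morpholin-4-yl or unsubstituted piperazin-1-yl at this same carbon on the core of compound 2 would address. Also open, on these data alone, is whether the same exchange would have a similar effect on a different core, and the series offers no measured information that accounts for the size of the step.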